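The compounds below may be only part of what the source reports. "The series", "measured", "known", "first", "only" and "open" are said of these compounds alone.

Measured in an ADME assay on microsomes from liver (Mus musculus, strain CD1) for metabolic stability, read by LC-MS, with a stated time of 1 h; a higher number here means that more of the compound is left, a lower number that less of the compound is left:
- Compound 1 `CCOc1ccccc1-c1ccc(CO[C@@H]2COc3nc([N+](=O)[O-])cn3C2)cc1`: 0.2%
- Compound 2 `O=[N+]([O-])c1cn2c(n1)OC[C@@H](OCc1ccc(-c3ccc(CNc4ccccc4)cc3)cc1)C2`: 52%

Compound 2, at 52%, has the higher of the two numbers. Compound 1, at 0.2%, lies lower, and the gap is well beyond the usual scatter. Compound 3 `CC(=O)c1ccc(-c2ccc(CO[C@@H]3COc4nc([N+](=O)[O-])cn4C3)cc2)cc1` comes from compound 2 through one change, acetyl in place of anilinomethyl on an aromatic carbon. Within the data shown here, no measured pair differs in just one place, so this change has no direct precedent and any forecast stays rough. Compound 1 also lacks the anilinomethyl group and gives only 0.2%, so a fall in this assay is the likelier direction. The expected change is a number 27 percentage points lower from compound 2 to compound 3 (beyond the scatter), a drop probably beyond the scatter. For compound 3, the estimated value is 25%, with an expected range from 3% to 60%.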

Compound 3, percent of the compound remaining: 70%
Compound 3: the middle estimate sits 45 percentage points below what was measured; the measured number lies above the stated range.
By their numbers in this assay, from the lowest: compound 1; then compound 2; then compound 3.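

In this assay, the anilinomethyl group is not needed for a high number at this place, on an aromatic carbon para to a large group: putting acetyl there gives a number 18 percentage points higher from compound 2 to compound 3 (beyond the scatter), a modest step, although acetyl is much the smaller group and brings no ring. Set against the 2-ethoxyphenyl group, the 4-acetylphenyl group gives a number 69.8 percentage points higher from compound 1 to compound 3 (beyond the scatter), a large step, but this swap alters both the substituent and where it sits on the ring, so it cannot say which of the two counts. No measurement at hand gives a reason for either rise.

On these data alone, whether acetyl itself matters, or whether any small group would serve here, stays open. A nitrile, a carboxylic acid or a plain methyl at the same place would begin to answer that.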